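Methoxy on the phenyl arm of the pyridinyl compound

The source may report more compounds than this note shows. Statements on the series, on what has been measured and on what is new or still open speak of the compounds shown alone.

Measured compounds:
compound 1 `O=C(O)Cc1sc(C(Cc2ccccc2)c2ccccc2)nc1-c1ccc(Cl)cc1` 56 nM
compound 2 `COc1ccc(C(c2ccccc2)c2nc(-c3ccc(Cl)cc3)c(CC(=O)O)s2)cc1` 8.4 nM
compound 3 `O=C(O)Cc1sc(C(c2ccccc2)c2ccccn2)nc1-c1ccc(Cl)cc1` 810 nM

In an in vitro assay on HEK385-7 cells for displacement of a labelled ligand from prostaglandin D2 receptor 2 (Homo sapiens) (a higher number here means a weaker inhibitor, a lower number a stronger inhibitor), compound 3 gives the highest number of the three, the weakest binder in this set: a 14-fold higher number from compound 1 to compound 3 (1.16 log units; beyond the scatter) and a 96-fold higher number from compound 2 to compound 3 (1.98 log units; beyond the scatter) both lie beyond the scatter.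

Compound 4 `COc1ccc(C(c2ccccn2)c2nc(-c3ccc(Cl)cc3)c(CC(=O)O)s2)cc1` keeps the pyridin-2-yl of compound 3 and differs only by methoxy in place of hydrogen on an aromatic carbon.

Going by the values given here, no measured pair carries a hydrogen-to-methoxy exchange on an otherwise unchanged phenyl, so the closest guide is a 6.7-fold lower number from compound 1 to compound 2 (0.82 log units; beyond the scatter), where a 4-methoxyphenyl also enters on the same saturated carbon, though there it displaces a benzyl rather than a hydrogen on a phenyl. That step was modest. Among the compounds with values here, the pyridin-2-yl partner is the other unknown: no pair shows how it responds to a change on the neighbouring aryl.

The step from compound 3 to compound 4 is therefore expected to be a lower number of roughly the same modest size, a 3.2-fold lower number from compound 3 to compound 4 (0.51 log units; beyond the scatter), with wide uncertainty. Compound 4 is estimated at 250 nM, range 90 nM to 700 nM.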

Compound 4, half-maximal inhibitory concentration: 61 nM
Compound 4: the middle estimate sits 4.1-fold (0.61 log units) above what was measured; the measured number lies below the stated range.
By their numbers in this assay, from the lowest: compound 2; then compounds 1 and 4 (each within the scatter of the next); then compound 3.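

In this assay, going by these compounds alone, methoxy in place of hydrogen on an aromatic carbon, para to a large group, gives a 13-fold lower number from compound 3 to compound 4 (1.12 log units; beyond the scatter): this is the first direct reading of the exchange, and the step is large with pyridin-2-yl as the partner aryl on the saturated carbon. With the 4-methoxyphenyl arm held constant, pyridin-2-yl in place of phenyl gives a 7.3-fold higher number from compound 2 to compound 4 (0.86 log units; beyond the scatter), so the methoxy gain seen on compound 4 does not bring it level with compound 2, and the two arms are shown to act on the number together rather than one masking the other. No measurement here gives a reason for the size of either step.

The size of the same hydrogen-to-methoxy exchange with phenyl as the partner aryl in place of pyridin-2-yl remains open, so the compounds shown cannot tell whether the step depends on that partner. Also open, going by these compounds, is whether the step belongs to methoxy itself or would also appear with a hydroxy group, a fluorine or a longer ethoxy chain at the same place on the ring.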